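The source may report more compounds than this note shows. Statements on the series, on what has been measured and on what is new or still open speak of the compounds shown alone.

Compound 1 `Cc1ccccc1C(=O)Nc1nnc(-c2ccc3c(c2)OCCO3)s1`, in a functional assay on BGC-823 cells (Homo sapiens) for antiproliferative activity, read by MTT assay, with a stated time of 48 h; a higher number here means that more compound is needed for the effect, a lower number that less compound is needed: > 100 ug/mL (a limit of the assay)
Compound 2 `O=C(Nc1nnc(-c2ccc3c(c2)OCCO3)s1)c1ccc(Cl)nc1`, in this assay : > 100 ug/mL (a limit of the assay)

In this assay compound 1 gives only the limit > 100 ug/mL. Compound 2 likewise gives only the limit > 100 ug/mL. Within the data shown here, the one measured step, a step that the two limits leave unreadable from compound 1 to compound 2, therefore cannot be read, since (the limit of > 100 ug/mL in this assay, at which 2 of the 2 values shown sit). Compound 3 `O=C(/C=C/c1ccccc1)Nc1nnc(-c2ccc3c(c2)OCCO3)s1` differs from compound 2 by 2-phenylethenyl in place of 6-chloropyridin-3-yl on a carbonyl carbon. No measured step bears on this change, so nothing shown argues for a readable move in either direction. Compound 3 is expected to sit near the same limit, estimated at 120 ug/mL (range 40 ug/mL to 400 ug/mL), an expected step that the limit leaves unreadable from compound 2 to compound 3.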

Compound 3, half-maximal effective concentration: 45.4 ug/mL
Compound 3: middle estimate off by 2.6-fold (0.42 log units), on the high side; low and high end bracket the measured number.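

The carbonyl carbon's substituent can move the read-out away from the limit in this assay: 2-phenylethenyl gives an at least 2.2-fold lower number from compound 2 to compound 3 (0.34 log units; beyond the scatter) and an at least 2.2-fold lower number from compound 1 to compound 3 (0.34 log units; beyond the scatter). Both steps are only minimum sizes, because each starts from a limit of the assay, and the step between compound 1 and compound 2 cannot be read: the limit of > 100 ug/mL in this assay, at which 2 of the 3 values shown sit.

The compounds shown do not separate the part played by the double bond from that of the phenyl ring, which a saturated 2-phenylethyl group would test. Going by these compounds, whether an amine on that phenyl ring would lower the number further also stays open.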